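Fluoro for Nitro on Two Related Cores

This account rests on a few compounds, and the source may have more. Where it says the series, first, only, none or still open, it means among the compounds named here.

Measured compounds:
compound 1, `COc1ccc2nc(-c3ccc(N/C=C\C(=O)c4ccc(OC)c([N+](=O)[O-])c4)cc3)sc2c1`, 17600 nM
compound 2, `COc1ccc(C(=O)/C=C\Nc2ccc(-c3nc4cc(OC)c(OC)c(OC)c4s3)cc2)cc1[N+](=O)[O-]`, 11400 nM
compound 3, `COc1ccc2nc(-c3ccc(N/C=C\C(=O)c4ccc(OC)c(F)c4)cc3)sc2c1`, 500 nM

Of the compounds shown here, three have been measured in a functional assay on HeLa cells (Homo sapiens) for antiproliferative activity, read by sulforhodamine B assay, with a stated time of 48 h; on this read-out higher numbers stand for weaker inhibition and lower numbers for stronger inhibition. In this assay compound 1 gives 17600 nM, compound 2 gives 11400 nM and compound 3 gives 500 nM. Compound 3 differs from compound 1 in one place: fluoro in place of nitro on an aromatic carbon This change produced a 35-fold lower number from compound 1 to compound 3 (1.55 log units; beyond the scatter). How the core of compound 2 differs from the core of compound 1 is not broken down here; the two numbers for compound 1 and compound 2 lie within the usual scatter of each other, so nothing separates them.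

Compound 4, `COc1ccc(C(=O)/C=C\Nc2ccc(-c3nc4cc(OC)c(OC)c(OC)c4s3)cc2)cc1F`, has not yet been measured. It differs from compound 2 in one place: fluoro in place of nitro on an aromatic carbon The surroundings of the place are described in the same words for both pairs, so this is the same change as the one from compound 1 to compound 3, seen for the second time among these compounds. For the measured compounds named here, compound 4 is expected to show a 29-fold lower number from compound 2 to compound 4 (1.45 log units; beyond the scatter) in this assay, beside the earlier step; this expectation rests only on the step from compound 1 to compound 3, a 35-fold lower number from compound 1 to compound 3 (1.55 log units; beyond the scatter), which is the sole precedent and therefore carries wide uncertainty. Compound 4 is accordingly estimated at 400 nM, with a range from 120 nM to 1500 nM.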

Compound 4, half-maximal inhibitory concentration: 7300 nM
The estimate for compound 4 lay 18-fold (1.26 log units) below the measured number; measured number above the stated range.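

On the core of compound 2, fluoro in place of nitro gives a 1.6-fold lower number from compound 2 to compound 4 (0.19 log units; within the scatter), so in this assay the 4-methoxy-3-nitrophenyl and 3-fluoro-4-methoxyphenyl forms of this core cannot be told apart. Set beside the earlier step, the change does not carry over at the same size from one core to the other, and a step seen on one core proved a poor guide to the other: the same change on two cores in this assay, a 35-fold lower number (1.55 log units; beyond the scatter) from compound 1 to compound 3 and a 1.6-fold lower number (0.19 log units; within the scatter) from compound 2 to compound 4, 23-fold (1.35 log units) apart, beyond the scatter of two such steps. This does not show why the two cores answer so differently, since the difference between them is not broken down into single changes, and two pairs set no rule for any further core in the series.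

Among the compounds shown, this place holds only nitro or fluoro, so it remains open how a chloro group, a nitrile or an amine there would read on either core, and whether any of them would also separate the two cores. Going by these compounds, it is also open which part of the core governs the size of the step, a question that pairs differing in a single place on the core itself could address.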